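The compounds below may be only part of what the source reports. "The series", "measured", "known", "first", "only" and "open" are said of these compounds alone.

Within the data shown here, in a functional assay on OVCAR-3 cells (Homo sapiens) for inhibition, read by MTT assay, with a stated time of 24 h (a lower number here means a stronger inhibitor, a higher number a weaker inhibitor), compound 3 `CC1(C)[C@H]2CC[C@]1(C)N(Cc1cn(-c3cccc(O)c3)nn1)C(=O)C2` gives 370 nM, the highest of the three numbers so far, which makes it the weakest inhibitor of the set. Two relatives share its core. Compound 1 `CC1(C)[C@H]2CC[C@]1(C)N(Cc1cn(-c3cccc(Cl)c3)nn1)C(=O)C2`, with a 3-chlorophenyl group, gives 50 nM, and compound 2 `Cc1ccc(-n2cc(CN3C(=O)C[C@@H]4CC[C@@]3(C)C4(C)C)nn2)cc1`, with a 4-methylphenyl group, gives 40 nM. These two cannot be told apart, as a 1.3-fold lower number from compound 1 to compound 2 (0.10 log units; within the scatter) shows.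

The next compound, compound 4 `CC1(C)[C@H]2CC[C@]1(C)N(Cc1cn(-c3ccc(Cl)cc3)nn1)C(=O)C2`, changes the same spot as those relatives: 4-chlorophenyl in place of 3-hydroxyphenyl on an aromatic nitrogen. In words, 4-chlorophenyl stands in place of 3-hydroxyphenyl on an aromatic nitrogen. Among the measured compounds shown here, two measured steps bear on this swap. They lead into the 3-hydroxyphenyl group of compound 3 from its two relatives: a 7.4-fold higher number from compound 1 to compound 3 (0.87 log units; beyond the scatter) and a 9.3-fold higher number from compound 2 to compound 3 (0.97 log units; beyond the scatter). Both are modest and beyond the scatter. For the measured compounds named here, the 4-chlorophenyl group has features of both relatives, the chloro of compound 1 and the ring placement named in compound 2, although no 4-chlorophenyl compound has been measured yet. Read in reverse, those steps point to a similar move in the opposite direction.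

In this assay, the expected change is an 8.2-fold lower number from compound 3 to compound 4 (0.91 log units; beyond the scatter), toward a lower number and beyond the scatter. For compound 4, the estimated value is 45 nM, with an expected range from 15 nM to 130 nM.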

Compound 4, half-maximal inhibitory concentration: 160 nM
Compound 4: middle estimate off by 3.6-fold (0.55 log units), on the low side; the measured number lies above the stated range.
By their numbers in this assay, from the lowest: compounds 2 and 1 (each within the scatter of the next); then compound 4; then compound 3.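

Swapping the 3-hydroxyphenyl group for 4-chlorophenyl in this assay gives a 2.3-fold lower number from compound 3 to compound 4 (0.36 log units; beyond the scatter), yet compound 4 does not reach the numbers of compound 1 and compound 2. The place of the chloro on the phenyl ring matters, as the change from 3-chlorophenyl to 4-chlorophenyl gives a 3.2-fold higher number from compound 1 to compound 4 (0.51 log units; beyond the scatter), so having a chloro on this ring does not by itself bring the low number of compound 1. Chloro and methyl also turn out not to be interchangeable on the same ring carbon, with chloro in place of methyl giving a 4.0-fold higher number from compound 2 to compound 4 (0.60 log units; beyond the scatter), a difference that the matching numbers of compound 1 and compound 2 gave no hint of.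

Nothing available here gives a reason for this order of the groups. Still open, from the compounds shown here alone, is how a 3-methylphenyl or a 4-hydroxyphenyl group would fare, since either would help separate the effect of the group itself from that of its place on the ring, and the same question stands for an amine on the phenyl ring.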